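This account rests on a few compounds, and the source may have more. Where it says the series, first, only, none or still open, it means among the compounds named here.

Compound 1 `O=C(O)CCc1ccncc1-c1ccc2ccccc2c1` carries a 2-carboxyethyl chain on its core. In a functional assay on HCT-116 cells (Homo sapiens) for inhibition, read by MTT assay, with a stated time of 72 h (on this read-out higher numbers stand for weaker inhibition of growth and lower numbers for stronger inhibition of growth), compound 1 gives > 30000 nM, which is a limit of the assay and not a number. Compound 2 `O=C(CCc1ccncc1-c1ccc2ccccc2c1)N1CCOCC1` differs from compound 1 only by morpholin-4-yl in place of hydroxy on a carbonyl carbon. In this assay compound 2 gives > 30000 nM, again only a limit. The step that the two limits leave unreadable from compound 1 to compound 2 therefore has no readable size. Compound 1 thus stands at the limit of > 30000 nM in this assay, at which 2 of the 2 values shown sit, and nothing places it more exactly. The change to compound 3 `O=C(O)/C=C/c1ccncc1-c1ccc2ccccc2c1` is 2-carboxyethenyl in place of 2-carboxyethyl on an aromatic carbon. Going by the values given here, no measured step bears on this change: the only step recorded, from compound 1 to compound 2, touches a different place and has no size of its own. Both values shown sit at the limit of > 30000 nM in this assay, at which 2 of the 2 values shown sit. Compound 3 is therefore expected to sit there as well, with the step of a number no higher from compound 1 to compound 3 (the limit leaves the size open) estimated as nothing beyond the scatter. Compound 3 is estimated at 30000 nM, with a range from 8000 nM to 100000 nM, and is expected most likely to be reported only as a limit.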

Compound 3, concentration for 50% growth inhibition: > 30000 nM
Compound 3 gave a limit, no number (the forecaster's own chance of this, stated with the estimate: 75%); the middle value lies on the limit itself.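

Compound 3, like compound 1, gives only a limit and not a number, so the step between them cannot be read, and the result adds one more compound to the same limit: the limit of > 30000 nM in this assay, at which 3 of the 3 values shown sit. The compounds shown leave open what change to this chain or the shared core, if any, would give a readable number in this assay.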